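Methoxy to trifluoromethyl on two related indole cores

The source may report more compounds than this note shows. Statements on the series, on what has been measured and on what is new or still open speak of the compounds shown alone.

Measured so far in a functional assay on MCF7 cells (Homo sapiens) for antiproliferative activity, with a stated time of 5 days; on this read-out lower numbers stand for stronger inhibition and higher numbers for weaker inhibition:
compound 1 `CCCCCc1ccc2[nH]c(-c3ccc(OC)cc3)c(C=O)c2c1`: 20 nM
compound 2 `CCCCCc1ccc2[nH]c(-c3ccc(C(F)(F)F)cc3)c(C=O)c2c1`: 67 nM
compound 3 `CCCCc1ccc2[nH]c(-c3ccc(OC)cc3)c(/C=N\C)c2c1`: 27 nM

Compound 1 and compound 2 share one core and differ in a single place: trifluoromethyl in place of methoxy on an aromatic carbon. In this assay that change gave a 3.4-fold higher number from compound 1 to compound 2 (0.53 log units; beyond the scatter), a step large enough to stand clear of the usual scatter of repeated measurements.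

Compound 3 carries a different core; how its core differs from that of compound 1 is not broken down here. In this assay compound 3 gives a number that lies within the scatter of the number for compound 1, so no order between the two can be drawn from these values. Against compound 2, compound 3 gives a lower number, and that gap lies beyond the scatter.

Compound 4 `CCCCc1ccc2[nH]c(-c3ccc(C(F)(F)F)cc3)c(/C=N\C)c2c1` is not yet measured. It stands to compound 3 as compound 2 stands to compound 1: trifluoromethyl in place of methoxy on an aromatic carbon. The place of the change is described in the same words in both pairs, so this is the same change made on the second core. Among the measured compounds shown here, the only guide to its size is the one measured instance, the step from compound 1 to compound 2. If the second core answers the change as the first did, compound 4 is expected to give a number higher than that of compound 3 by about a 3.1-fold higher number from compound 3 to compound 4 (0.50 log units; beyond the scatter). On that basis the estimate for compound 4 in this assay is 85 nM, with a likely range from 40 nM to 200 nM.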

Compound 4, half-maximal inhibitory concentration: 140 nM
Estimate against measurement, compound 4: 1.6-fold (0.22 log units) below, within the range that was stated.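

In this assay, trifluoromethyl in place of methoxy on the second core gave a 5.2-fold higher number from compound 3 to compound 4 (0.71 log units; beyond the scatter), so the direction seen on the first core held here as well. Set side by side, the two steps do not differ by more than the scatter allows, and the change carried over from one core to the other in both direction and size: the same change on two cores in this assay, a 3.4-fold higher number (0.53 log units; beyond the scatter) from compound 1 to compound 2 and a 5.2-fold higher number (0.71 log units; beyond the scatter) from compound 3 to compound 4, 1.5-fold (0.19 log units) apart, within the scatter of two such steps. Among the compounds shown here, this agreement rests on only two pairs in a single assay, so it supports carrying the change between these two cores but does not show that it would carry to any further core, and it does not explain why the number rises in both pairs.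

The compounds shown hold only methoxy and trifluoromethyl at this place on the aromatic ring, so it remains open how a chlorine atom, a hydroxyl group or an amine would compare there on either core. Going by these compounds, it also remains open whether a step of similar size would appear on a core bearing a longer chain or a carboxylic acid.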